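Benzoyl on the Phenoxy Ring: Expected Cytotoxicity

The source may report more compounds than this note shows. Statements on the series, on what has been measured and on what is new or still open speak of the compounds shown alone.

Compound 1 `NC(=S)Nc1cccc(OCCCCCCc2ccccc2)c1`: 28000 nM
Compound 2 `NC(=S)Nc1cccc(OCCCCCOc2ccccc2)c1`: > 50000 nM (a limit)
Compound 3 `NC(=S)Nc1cccc(OCCCCCOc2ccc(Br)cc2)c1`: 19000 nM

In an ADME assay on Ava5 cells (Homo sapiens) for cytotoxicity (a higher number here means that more compound is tolerated, a lower number that less compound is tolerated), compound 1 gives 28000 nM and compound 3 gives 19000 nM. For compound 2 the assay reports only a limit, > 50000 nM. Compound 2 therefore stands at the limit of > 50000 nM in this assay, at which 1 of the 3 values shown sits, so its true position is open.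

Compound 4 `NC(=S)Nc1cccc(OCCCCCOc2cccc(C(=O)c3ccccc3)c2)c1` differs from compound 2 by benzoyl in place of hydrogen on an aromatic carbon. The step that bears on it is the other substitution on the same ring, an at least 2.6-fold lower number from compound 2 to compound 3 (0.42 log units; beyond the scatter), which moved the number below the limit. The steps of an at least 1.7-fold higher number from compound 1 to compound 2 (0.25 log units; that floor lies within the scatter) and a 1.5-fold lower number from compound 1 to compound 3 (0.17 log units; within the scatter) frame that ring against the benzyl chain end. For compound 4 a lower number in this assay is therefore expected, an at least 3.3-fold lower number from compound 2 to compound 4 (0.52 log units; beyond the scatter), since compound 3 showed an at least 2.6-fold lower number from compound 2 to compound 3 (0.42 log units; beyond the scatter). The estimate for compound 4 is 15000 nM, with a range from 5000 nM to 45000 nM.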

Compound 4, half-maximal cytotoxic concentration: 13000 nM
Estimate against measurement, compound 4: 1.2-fold (0.06 log units) above, and the stated range covers the measured number.
By their numbers in this assay, from the lowest: compounds 4, 3 and 1 (each within the scatter of the next, the first and the last beyond it). At a limit, above all of these: compound 2.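

In this assay, benzoyl in place of hydrogen on an aromatic carbon, meta to a large group, gives an at least 3.8-fold lower number from compound 2 to compound 4 (0.58 log units; beyond the scatter). A drop beyond the scatter on this ring is thus not confined to bromo, and it also appears with a group that brings a second aromatic ring. The true size of the step stays unknown, as compound 2 stands at a limit: the limit of > 50000 nM in this assay, at which 1 of the 4 values shown sits.

On these data alone, whether the lower number follows the carbonyl or the added aromatic ring stays open. So does how an amine or a carboxylic acid at this position would read in this assay.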